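A few compounds are considered here, and "the series" means these few. Any claim that something is new, unique, unknown or untested is made for them only; others in the source may bear on it.

Working notes on the series in a functional assay on MCF7 cells (Homo sapiens) for antiproliferative activity, read by MTT assay, with a stated time of 48 h; on this read-out higher numbers stand for weaker inhibition and lower numbers for stronger inhibition.

Within the data shown here, compound 1 `N#CC1=C(N)Oc2c(c3nc4ccccc4nc3c3ccccc23)C12C(=O)N(Cc1cnnn1-c1ccc(Br)cc1)c1ccccc12` gives 36600 nM in this assay and is the only member with a measured number. Compound 2 `CC(=O)Nc1ccc(-n2nncc2CN2C(=O)C3(C(C#N)=C(N)Oc4c3c3nc5ccccc5nc3c3ccccc43)c3ccccc32)cc1` carries an acetamido group where compound 1 carries bromo. In this assay compound 2 gives > 50000 nM, which is a limit of the assay and not a number. The step of an at least 1.3-fold higher number from compound 1 to compound 2 (0.13 log units; that floor lies within the scatter) therefore runs from a number to a limit, and the limit of > 50000 nM in this assay, at which 1 of the 2 values shown sits, is where compound 2 sits; on the numbers shown, compound 2 stands at the weak end of the series, with no point value of its own.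

Compound 3 `N#CC1=C(N)Oc2c(c3nc4ccccc4nc3c3ccccc23)C12C(=O)N(Cc1cnnn1-c1ccc(S(N)(=O)=O)cc1)c1ccccc12` is the next step from compound 2: sulfamoyl in place of acetamido on an aromatic carbon. Among the measured compounds shown here, no measured step in this assay involves a sulfamoyl group, so the only step that bears on this change is an at least 1.3-fold higher number from compound 1 to compound 2 (0.13 log units; that floor lies within the scatter), which itself is only a floor within the scatter. For the measured compounds named here, with compound 2 at a limit and no measured step speaking for a direction, nothing beyond the scatter is expected in either direction, and a limit result for compound 3 remains a real possibility.

Compound 3 is estimated at 45000 nM, with a range from 18000 nM to 100000 nM. This corresponds to an expected step of an at least 1.1-fold lower number from compound 2 to compound 3 (0.04 log units; that floor lies within the scatter).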

Compound 3, half-maximal inhibitory concentration: > 50000 nM
Compound 3: only a limit was reported; the forecaster's own chance of this, stated with the estimate: 45%; at least 1.1-fold (0.04 log units) between middle value and limit.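

In this assay compound 3 gives a limit of the assay and not a number, the same limit as for compound 2, so the step between those two cannot be read and sulfamoyl and acetamido cannot be ranked. Against bromo, on an aromatic carbon para to a large group, the new change reads an at least 1.3-fold higher number from compound 1 to compound 3 (0.13 log units; that floor lies within the scatter), which is again only a floor, so neither replacement of bromo is shown to move the read-out beyond the scatter. A second, different group now ends at the limit, which makes the limit the most common result among the compounds shown: the limit of > 50000 nM in this assay, at which 2 of the 3 values shown sit.

Among these compounds, compound 1, at 36600 nM, remains the only point value, so the size of any effect of the group at this place stays unknown. Open, on these data alone, is whether an amine, a carboxylic acid or a methoxy group on the same aromatic carbon would give a measurable number, and whether any such group would differ from bromo by more than the scatter.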